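Hydroxy to Methoxy in Three Antiproliferative Compounds

The source may report more compounds than this note shows. Statements on the series, on what has been measured and on what is new or still open speak of the compounds shown alone.

Compound 1 `COc1cccc(/C=C/C(=O)C(=Cc2cc(OC)c(OC)c(OC)c2)C(=O)/C=C/c2cccc(OC)c2OC)c1OC` — 400 nM
Compound 2 `COc1cc(C=C(C(=O)/C=C/c2cccc(OC)c2OC)C(=O)/C=C/c2cccc(OC)c2OC)cc(OC)c1O` — 300 nM
Compound 3 `COc1ccc(OC)c(/C=C/C(=O)C(=Cc2ccc(O)c(OC)c2)C(=O)/C=C/c2cc(OC)ccc2OC)c1` — 340 nM

Three compounds were measured in a functional assay on CNE-2 cells (Homo sapiens) for antiproliferative activity, read by sulforhodamine B assay, with a stated time of 48 h; on this read-out lower numbers stand for stronger inhibition and higher numbers for weaker inhibition. Compound 1 gives 400 nM, compound 2 gives 300 nM and compound 3 gives 340 nM; all three values lie within the usual scatter of one another, so no order among them can be drawn.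

Compound 1 arises from compound 2 by a single change, (methyl in place of hydrogen on an oxygen on an aromatic ring), and this step produced a 1.3-fold higher number from compound 2 to compound 1 (0.12 log units; within the scatter). The difference between the core of compound 2 and the core of compound 3 is not broken down here.

Compound 4 `COc1ccc(OC)c(/C=C/C(=O)C(=Cc2ccc(OC)c(OC)c2)C(=O)/C=C/c2cc(OC)ccc2OC)c1` has not yet been measured in this assay . It arises from compound 3 by methyl in place of hydrogen on an oxygen on an aromatic ring. The place of the change is described in the same words as for the step from compound 2 to compound 1, so it is the same change, made on a different core.

The expected step in this assay is a 1.2-fold higher number from compound 3 to compound 4 (0.07 log units; within the scatter), which rests on compound 2 and compound 1 showing a 1.3-fold higher number from compound 2 to compound 1 (0.12 log units; within the scatter) for the same change. Since that earlier step stayed within the scatter, compound 4 is estimated at 400 nM, with a plausible range from 180 nM to 900 nM. The estimate rests on a single precedent and carries the uncertainty of that.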

Compound 4, half-maximal inhibitory concentration: 550 nM
The estimate for compound 4 lay 1.4-fold (0.14 log units) below the measured number, within the range that was stated.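

In this assay, replacing the hydroxy group with a methoxy group on the core of compound 3 gives a 1.6-fold higher number from compound 3 to compound 4 (0.21 log units; within the scatter). Set beside the earlier case of this change, the two steps agree: the same change on two cores in this assay, a 1.3-fold higher number (0.12 log units; within the scatter) from compound 2 to compound 1 and a 1.6-fold higher number (0.21 log units; within the scatter) from compound 3 to compound 4, 1.2-fold (0.08 log units) apart, within the scatter of two such steps. This shows that, on these two cores, methyl can take the place of hydrogen on an oxygen on an aromatic ring without a step that can be told from the scatter, and the change carries over with no detectable dependence on the core; it does not show that the same would hold on any further core, and two pairs of compounds offer no explanation for the result.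

The compounds shown carry only hydroxy or methoxy at the site of the change, leaving open what an amine, a carboxylic acid or a longer alkoxy chain would do there. Also open, going by these compounds, is whether the step would remain this small on a core in which one of the other methoxy groups had been replaced by one of those groups.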